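The source may report more compounds than this note shows. Statements on the series, on what has been measured and on what is new or still open speak of the compounds shown alone.

Measured so far:
compound 1 `CC(C)(C)c1ccc(CNCCCNS(=O)(=O)c2cc(C(F)(F)F)cc(C(F)(F)F)c2)cc1` gives 2300 nM;
compound 2 `O=S(=O)(NCCCCCCNCc1ccc(Br)cc1)c1ccccc1F` gives 13300 nM.

Among the compounds with values here, in a functional assay on MIA PaCa-2 cells (Homo sapiens) for inhibition, read by MTT assay, with a stated time of 72 h (on this read-out higher numbers stand for weaker inhibition of growth and lower numbers for stronger inhibition of growth), compound 1 stands lowest of the two numbers, and compound 2 sits a good deal higher, a gap beyond the usual scatter; no single change links these two, so the pair shows only that compound 1 is the stronger inhibitor of the two.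

Compound 3 `O=S(=O)(NCCCNCc1ccc(Cl)cc1)c1cc(C(F)(F)F)cc(C(F)(F)F)c1` keeps the core of compound 1 and differs in one place: chloro in place of tert-butyl on an aromatic carbon. Within the data shown here, no measured pair with this same change exists here, so the direction of the step is uncertain. A smaller group enters where a bulky one leaves, and the expected step is a modest weakening, near the edge of the scatter rather than clearly beyond it, which is the size meant by a 1.5-fold higher number from compound 1 to compound 3 (0.18 log units; within the scatter). Compound 3 is therefore estimated at 3500 nM, with a likely range from 1500 nM to 9000 nM.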

Compound 3, concentration for 50% growth inhibition: 2800 nM
For compound 3 the middle estimate is 1.3-fold (0.10 log units) above the measured one; the range from low to high includes it.
By their numbers in this assay, from the lowest: compounds 1 and 3 (each within the scatter of the next); then compound 2.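

Within the data shown here, replacing the 4-(tert-butyl)benzyl group with 4-chlorobenzyl is the first single change that can be read in this assay, and it gives a 1.2-fold higher number from compound 1 to compound 3 (0.09 log units; within the scatter). Four heavy atoms leave and one enters on this aromatic carbon, yet the two compounds cannot be told apart on this read-out, so for this pair the tert-butyl group is not needed to keep the number where it stands. Nothing available here explains this result.

As far as these compounds go, whether this carbon accepts other groups stays open, as a methoxy group, an amine or a carboxylic acid in the same place could give a quite different number. The chain is also unsettled, since compound 2 differs from compound 1 in more than one place, and only a longer chain on the core of compound 1 would test it directly.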